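Shortening the side chain on the shared core

This account rests on a few compounds, and the source may have more. Where it says the series, first, only, none or still open, it means among the compounds named here.

Compound 1, `COc1ccc(-c2nc(/N=C(\N)N(C)C)sc2-c2ccc(OC)cc2)cc1`: 37 nM in a functional assay with Oryctolagus cuniculus as the target; on this read-out higher numbers stand for weaker inhibition and lower numbers for stronger inhibition
Compound 2, `COc1ccc(-c2nc(CNC(C)=O)sc2-c2ccc(OC)cc2)cc1`: 15 nM

Both compounds share a core carrying two 4-methoxyphenyl groups and differ only in the group on the remaining aromatic carbon. In this assay compound 2 gives the lowest of the two numbers; compound 1 is the nearest, and the step of a 2.5-fold lower number from compound 1 to compound 2 (0.39 log units; beyond the scatter) lies beyond the scatter. Compound 3, `COc1ccc(-c2nc(C(N)=O)sc2-c2ccc(OC)cc2)cc1`, changes the same position: carbamoyl in place of acetamidomethyl on an aromatic carbon. The group shrinks from 5 heavy atoms to 3 while keeping 1 hydrogen-bond donor and 1 hydrogen-bond acceptor. Among the measured compounds shown here, the only measured step touching this position was modest, which suggests changes here move the number moderately, but no step tests a shorter group, so the direction is uncertain. A modest weakening is expected, a 2.0-fold higher number from compound 2 to compound 3 (0.30 log units; within the scatter). Compound 3 is therefore estimated at 30 nM, within a range from 8 nM to 120 nM.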

Compound 3, half-maximal inhibitory concentration: > 1000 nM
Compound 3: no number, only a limit; the forecaster's own chance of this, stated with the estimate: 5%; middle value at least 33-fold (1.52 log units) from the limit.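

Compound 3 yields a limit of the assay, not a number: the limit of > 1000 nM in this assay, at which 1 of the 3 values shown sits.

Even so, the change is large, with an at least 66-fold higher number from compound 2 to compound 3 (1.82 log units; beyond the scatter) when carbamoyl replaces acetamidomethyl, and an at least 27-fold higher number from compound 1 to compound 3 (1.43 log units; beyond the scatter) in the comparison with the other earlier group. The earlier compounds shown here showed only a modest step at this position, whereas this result shows that the position can move the number much further. Acetamidomethyl and carbamoyl have the same hydrogen-bond donor and acceptor counts, so those counts alone do not keep the number low.

The compounds shown cannot separate the effect of the shorter group from that of other differences between these groups. Going by these compounds, whether a plain amine or a longer amide chain at this position would keep the number low also remains open.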